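Removal of the phenethyl arm from compound 3

This account rests on a few compounds, and the source may have more. Where it says the series, first, only, none or still open, it means among the compounds named here.

Measured compounds, inhibition in an assay on isolated protein for inhibition of Indoleamine 2,3-dioxygenase 1 (Homo sapiens), with a stated time of 60 min, tested at 10 uM; on this read-out lower numbers stand for less inhibition and higher numbers for more inhibition at the one concentration tested (going by the name of the read-out):
- compound 1 `Clc1ccc2[nH]c(SCc3ccccc3Oc3ccccc3)nc2c1`: 30%
- compound 2 `Clc1ccc2[nH]c(SCc3ccccc3CCc3ccccc3)nc2c1`: 47%
- compound 3 `c1ccc(CCc2ccccc2CSc2nc3ccccc3[nH]2)cc1`: 43%

Compound 3 stands second highest of the three numbers in this assay; against compound 2 the gap is within the scatter, against compound 1 it is beyond it. Of the measured steps, only the change from compound 2 to compound 3 touches compound 3 directly, and it is small: a number 4 percentage points lower from compound 2 to compound 3 (within the scatter). The step from compound 1 to compound 2, a number 17 percentage points higher from compound 1 to compound 2 (beyond the scatter), shows that swapping the group on that aromatic carbon matters, though neither step removes the group outright.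

Compound 4 `c1ccc(CSc2nc3ccccc3[nH]2)cc1` follows from compound 3 by hydrogen in place of phenethyl on an aromatic carbon. Going by the values given here, no measured step mirrors a loss of this whole group, so the expectation rests on compound 3 alone, with a downward lean. Compound 4 is therefore expected to show a step of a number 21 percentage points lower from compound 3 to compound 4 (beyond the scatter), giving an estimated 22% with a range from 5% to 42%.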

Compound 4, a percentage reported as inhibition, at one concentration (the size of the read-out at that concentration, not a potency): -42%
Compound 4: middle estimate off by 64 percentage points, on the high side; the whole stated range lies above it.
By their numbers in this assay, from the lowest: compound 4; then compound 1; then compounds 3 and 2 (each within the scatter of the next).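

In this assay, hydrogen in place of phenethyl gives a number 85 percentage points lower from compound 3 to compound 4 (beyond the scatter), a far larger change than the swap of phenoxy for phenethyl in a number 17 percentage points higher from compound 1 to compound 2 (beyond the scatter), so at this aromatic carbon the presence of an arm matters more than the choice between these two arms. Compound 4 reads -42%, on the negative side of zero, so with hydrogen at this carbon the read-out shows no inhibition at the one concentration tested. No supporting data bear on the reason for this drop.

Going by these compounds, whether a single phenyl or a plain propyl chain at this carbon would restore any of the number stays open. Also open, on these data alone, is whether an amine or a carboxylic acid on the end of the phenethyl arm would leave the number higher, lower or level, and whether chloro on the core of compound 4 would change its reading.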